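A Side-Chain Swap Among Three Level Compounds

The source may hold more compounds than are shown below. What is called first, only, known or untested is meant among the compounds shown, and "the series" means these compounds.

Compound 1 `COc1cccc2cc(-c3ccccc3)c(O)nc12` gives 10000 nM in a functional assay on A549 cells (Homo sapiens) for cytotoxicity, read by colorimetric assay and MTT assay; a higher number here means a weaker inhibitor, a lower number a stronger inhibitor
Compound 2 `COc1cc(OC)c2cc(-c3ccccc3)c(O)nc2c1` gives 10000 nM in this assay
Compound 3 `CCN(CC)C(=O)Cn1c(=O)c(-c2ccc(OC)cc2)cc2c(OC)cc(OC)cc21` gives 10000 nM in this assay

Compound 3 stands level with compound 1 and compound 2, with no difference at the digits shown and nothing beyond the usual scatter of repeated measurements.

Compound 4 `COC(=O)CCn1c(=O)c(-c2ccc(OC)cc2)cc2c(OC)cc(OC)cc21` has not yet been measured. It keeps the core of compound 3 and changes one group: (methoxycarbonyl)methyl in place of diethylcarbamoyl on a saturated chain carbon bound to an aromatic nitrogen and nothing else. Cut one bond further out, the same difference reads (diethylcarbamoyl)methyl to 2-(methoxycarbonyl)ethyl.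

Among the compounds with values here, no pair of measured compounds differs in only one place, so the data offer no direct guide to this change. Within the data shown here, the only anchor is that compound 3 at 10000 nM matches the other two compounds, and none of the three goes against that level. In this assay no step beyond the scatter is therefore expected, and no direction is favoured. The estimated step of no change at the digits printed from compound 3 to compound 4 (within the scatter) is expected to be small. The expected value for compound 4 is 10000 nM with an estimated range from 4000 nM to 25000 nM as the likely span.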

Compound 4, half-maximal inhibitory concentration: 10000 nM
Estimate against measurement, compound 4: no gap at the digits printed, within the range that was stated.
By their numbers in this assay, from the lowest: compounds 1, 2, 3 and 4 (each within the scatter of the next).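

Within the data shown here, replacing diethylcarbamoyl with (methoxycarbonyl)methyl on a saturated chain carbon bound to an aromatic nitrogen is the first single change that can be read in this assay, and it gives no change at the digits printed from compound 3 to compound 4 (within the scatter). This swap takes out a group of 7 heavy atoms that holds a nitrogen and puts in one of 5 heavy atoms with two oxygens, yet this read-out does not separate the amide of compound 3 from the ester of compound 4, so at this position the change from one to the other makes no difference that can be seen here. No measured information is available to explain this result.

On these data alone, what remains open is whether any group at this position can shift the value at all, as a single flat step cannot show that; a carboxylic acid, an amine or a longer chain ending in an ester would each test this more widely. As far as these compounds go, it is also open whether the same swap would behave in the same way on the core of compound 1 or on any other core.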